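Little Movement Expected from a Ring Swap

The compounds below may be only part of what the source reports. "The series", "measured", "known", "first", "only" and "open" are said of these compounds alone.

- Compound 1 `Cc1cc(=O)c2c(O)c(CN3CCN(C(=O)OC(C)(C)C)CC3)c(O)c([C@H]3CCN(C)C[C@H]3O)c2o1` gives 6%
- Compound 2 `Cc1oc2c([C@H]3CCN(C)C[C@H]3O)c(O)cc(O)c2c(=O)c1C(O)c1ccc([N+](=O)[O-])cc1` gives 2%
- Compound 3 `Cc1oc2c([C@H]3CCN(C)C[C@H]3O)c(O)cc(O)c2c(=O)c1C(O)c1ccccc1Br` gives 10%

These values come from a functional assay on MIA PaCa-2 cells (Homo sapiens) for inhibition, read by MTT assay, with a stated time of 48 h, tested at 10 uM; on this read-out higher numbers stand for more inhibition of growth at the one concentration tested and lower numbers for less inhibition of growth. Compound 3, at 10%, lies within the usual scatter of both other compounds, so the three cannot be ranked on these numbers.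

The next compound to be tested is compound 4 `Cc1oc2c([C@H]3CCN(C)C[C@H]3O)c(O)cc(O)c2c(=O)c1C(O)c1c(Cl)cccc1Cl`. It carries 2,6-dichlorophenyl in place of 2-bromophenyl on a saturated chain carbon bound to an aromatic carbon and an oxygen on a saturated carbon. The counted difference is 2,6-dichlorophenyl in place of 2-bromophenyl on a saturated chain carbon bound to an aromatic carbon and an oxygen on a saturated carbon.

Within the data shown here, only one measured step changes the group at this same place. There, 2-bromophenyl replaces 4-nitrophenyl, giving a number 8 percentage points higher from compound 2 to compound 3 (within the scatter). Even that exchange of two quite different groups did not move the number beyond the scatter. Among the measured compounds shown here, no measured step connects compound 1 with the others, so it offers only a further low value. For the measured compounds named here, one step is thin evidence, and no measured compound carries the 2,6-dichlorophenyl group. On this basis, no change beyond the scatter is expected in this assay, in either direction.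

The estimated change is a number 2 percentage points lower from compound 3 to compound 4 (within the scatter). Compound 4 is expected to give about 8%, with an estimated range of 0% to 22%.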

Compound 4, percent growth inhibition at one concentration: 0%
Compound 4: middle estimate off by 8 percentage points, on the high side, and the stated range covers the measured number.
By their numbers in this assay, from the lowest: compounds 4, 2, 1 and 3 (each within the scatter of the next).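

In this assay, 2,6-dichlorophenyl in place of 2-bromophenyl gives a number 10 percentage points lower from compound 3 to compound 4 (within the scatter) and is the largest step yet at this place, while the same group in place of 4-nitrophenyl gives a number 2 percentage points lower from compound 2 to compound 4 (within the scatter) on the same carbon. Among these compounds, three differently substituted phenyl groups on the saturated chain carbon now lie within the scatter of one another, so the single earlier step has grown into a small set in which swapping these substituents, even one bromine for two chlorines, separates no pair of compounds. Nothing available here ties these numbers to any measured property of the groups.

As far as these compounds go, all three groups are phenyl rings, so it remains open whether something of another kind on this carbon, such as an amine, a carboxylic acid or a longer alkyl chain, would move the number beyond the scatter. Among the compounds shown here, it also remains open how the changes in compound 1, which has no single-place step to the others, bear on this series, and whether these compounds would separate at any other concentration.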